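The compounds below may be only part of what the source reports. "The series", "measured", "known", "first", "only" and "open" are said of these compounds alone.

Working notes on the series. Within the data shown here, compound 1 `O=C(Nc1cccc(-n2cc(-c3ccncc3)c(-c3cc(O)cc(Cl)c3)n2)c1)Nc1ccc(Cl)c(C(F)(F)F)c1` is one of two compounds so far measured in a functional assay on NCI-H522 cells (Homo sapiens) for inhibition, read by sulforhodamine B assay, with a stated time of 48 h, tested at 1 uM; on this read-out lower numbers stand for a stronger effect and higher numbers for a weaker effect at the one concentration tested; compound 1 gives 51%. Compound 2 `O=C(Nc1cccc(-n2cc(-c3ccncc3)c(-c3cc(O)cc(Cl)c3)n2)c1)Nc1ccc(Cl)c(Cl)c1` is the other; in this assay compound 2 gives 54%. Among the measured compounds shown here, the only step measured between compounds differing in one place is a number 3 percentage points higher from compound 1 to compound 2 (within the scatter), a chloro in place of trifluoromethyl on an aromatic carbon. Compound 1 and compound 2 thus lie within the scatter of each other, and neither can be set apart from the other on these numbers.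

Compound 3 `COc1cc(Cl)cc(-c2nn(-c3cccc(NC(=O)Nc4ccc(Cl)c(C(F)(F)F)c4)c3)cc2-c2ccncc2)c1` has not yet been measured. Against compound 1 it differs as follows: methyl in place of hydrogen on an oxygen on an aromatic ring. For the measured compounds named here, no measured step touches the oxygen on the 3-chloro-5-hydroxyphenyl ring, so nothing measured bears on this change directly; the one step that has been measured sits elsewhere in the molecule and was within the scatter. Going by the values given here, with no relevant step to draw on, the step of a number 4 percentage points higher from compound 1 to compound 3 (within the scatter) is expected to stay within the scatter. Compound 3 is estimated at 55% in this assay, within a range from 35% to 75%.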

Compound 3, a percentage reported as activity, at one concentration (the size of the read-out at that concentration, not a potency): 34%
Compound 3: middle estimate off by 21 percentage points, on the high side; measured number below the stated range.
By their numbers in this assay, from the lowest: compound 3; then compounds 1 and 2 (each within the scatter of the next).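

Among these compounds, the oxygen on the 3-chloro-5-hydroxyphenyl ring is the first place where a single change is seen to move the read-out beyond the scatter: in this assay, hydroxy to methoxy gives a number 17 percentage points lower from compound 1 to compound 3 (beyond the scatter), whereas the only earlier step, at the other end of the molecule, was a number 3 percentage points higher from compound 1 to compound 2 (within the scatter). On this read-out the lower number stands for a stronger effect at the one concentration tested, so the hydrogen on this oxygen is not required for the effect, and methyl in its place gives a stronger effect in this pair. Nothing available explains the step, and it shows only that this position responds to the change.

Going by these compounds, it remains open whether the gain is specific to methyl or would extend to a longer chain such as ethoxy, or to replacing the oxygen with an amine or a fluorine. On these data alone, it is also open whether the same change gives a similar step on the dichlorophenyl urea of compound 2, and whether the stronger effect at the one concentration tested would also be seen at other concentrations.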